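The source may hold more compounds than are shown below. What is called first, only, known or untested is meant among the compounds shown, and "the series" means these compounds.

Working notes on the series. Compound 1, `COc1ccc2nc(C)cc(OCc3ccc4ccccc4n3)c2c1`, gives 21000 nM in a physicochemical assay for solubility, in phosphate buffer, measured as kinetic solubility, with a stated time of 1 h, at pH 7.4; a lower number here means a less soluble compound, a higher number a more soluble compound. Compound 2, `COc1ccc2nc(C)cc(OCC(=O)Nc3ccc(Br)c(C)c3)c2c1`, is the second member with an amide-linked side chain on the shared core. In this assay compound 2 reaches only a limit, reported as < 1000 nM, so its true value is not known beyond that. Among the measured compounds shown here, compound 2 therefore stands at the limit, (the limit of < 1000 nM in this assay, at which 1 of the 2 values shown sits), rather than at a number, and no step between the two measured compounds can be sized.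

Compound 3, `COc1ccc2nc(C)cc(OCC(=O)Nc3noc(C)c3C)c2c1`, is not yet measured. It differs from compound 2 by 4,5-dimethyl-1,2-oxazol-3-yl in place of 4-bromo-3-methylphenyl on an amide-type nitrogen. No measured step covers a change of this kind in the series. For compound 3 in this assay an upward step is expected, an at least 3.0-fold higher number from compound 2 to compound 3 (0.47 log units; beyond the scatter), moving away from the limit where compound 2 sits. The estimate for compound 3 is 3000 nM, with a range from 800 nM to 12000 nM, the measured outcome pending.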

Compound 3, solubility: 196000 nM
The estimate for compound 3 lay 65-fold (1.82 log units) below the measured number, outside the stated range (above it).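

On the amide-type nitrogen, 4,5-dimethyl-1,2-oxazol-3-yl in place of 4-bromo-3-methylphenyl gives, in this assay, an at least 190-fold higher number from compound 2 to compound 3 (2.29 log units; beyond the scatter). Among the compounds shown here, the earlier compounds offered no step that could be sized, and this is the first sign that the group at this place can shift the number well beyond the scatter. The step is a minimum and its true size remains unknown, because compound 2 sits at a limit: the limit of < 1000 nM in this assay, at which 1 of the 3 values shown sits.

One step swaps the whole ring, and the compounds shown do not separate the loss of the bromine from the change to a five-membered aromatic ring with 2 hetero atoms. From the compounds shown here alone, whether an unsubstituted phenyl, a pyridine or a ring carrying a carboxylic acid would give a similar number at this place remains open.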